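The source may hold more compounds than are shown below. What is called first, only, known or untested is meant among the compounds shown, and "the series" means these compounds.

In a functional assay on NCI-H460 cells (Homo sapiens) for cytotoxicity, read by MTT assay, with a stated time of 48 h (on this read-out lower numbers stand for stronger inhibition and higher numbers for weaker inhibition), compound 1 `C=C1C(=O)O[C@H]2CC3=C[C@H](C/C(C)=C/[C@@H](OC(=O)c4ccc(C(F)(F)F)cc4)[C@H]12)OC3=O` is reported only as a limit, > 10000 nM. Compound 2 `C=C1C(=O)O[C@H]2CC3=C[C@H](C/C(C)=C/[C@@H](OC(=O)/C=C/c4ccc(C(F)(F)F)cc4)[C@H]12)OC3=O` gives 1400 nM and compound 3 `C=C1C(=O)O[C@H]2CC3=C[C@H](C/C(C)=C/[C@@H](OC(=O)CC4CCCCC4)[C@H]12)OC3=O` gives 2000 nM. Among the compounds with values here, these two numbers lie within the usual scatter of each other, so compound 3 stands level with compound 2, and these are the only two exact numbers so far.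

Compound 4 `C=C1C(=O)O[C@H]2CC3=C[C@H](C/C(C)=C/[C@@H](OC(=O)/C=C/c4cccs4)[C@H]12)OC3=O` has not yet been measured. It keeps the shared core of compound 3 and alters only the group on a carbonyl carbon, where 2-(thiophen-2-yl)ethenyl takes the place of cyclohexylmethyl: 2-(thiophen-2-yl)ethenyl in place of cyclohexylmethyl on a carbonyl carbon.

Within the data shown here, only one measured step changes a group at this place: an at least 5.0-fold lower number from compound 1 to compound 3 (0.69 log units; beyond the scatter). One end of that step is a limit, and it involves neither group of the present change, so it offers only a weak guide. The closest measured relative is compound 2, which also carries an ethenyl group ending in an aromatic ring and gives 1400 nM. That value sits within the scatter of compound 3, so no step beyond the scatter is expected here.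

The estimated change is a 1.3-fold lower number from compound 3 to compound 4 (0.12 log units; within the scatter). For compound 4, the expected value in this assay is 1500 nM, with an estimated range of 500 nM to 5000 nM.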

Compound 4, half-maximal inhibitory concentration: 2900 nM
For compound 4 the middle estimate is 1.9-fold (0.29 log units) below the measured one; the measured number falls inside the stated range.
By their numbers in this assay, from the lowest: compounds 2, 3 and 4 (each within the scatter of the next, the first and the last beyond it). At a limit, above all of these: compound 1.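

At this place on a carbonyl carbon, 2-(thiophen-2-yl)ethenyl in place of cyclohexylmethyl gives a 1.5-fold higher number from compound 3 to compound 4 (0.16 log units; within the scatter) in this assay, so a saturated ring and an aromatic ring on an ethenyl chain can read alike here. Within the data shown here, with the ethenyl chain kept, thiophen-2-yl in place of 4-(trifluoromethyl)phenyl gives a 2.1-fold higher number from compound 2 to compound 4 (0.32 log units; beyond the scatter), the first step at this place with exact numbers at both ends that lies beyond the scatter, though only modestly, and so the ring at the end of the chain has some bearing on the result. The 2-(thiophen-2-yl)ethenyl group also separates from the group of compound 1, with an at least 3.4-fold lower number from compound 1 to compound 4 (0.53 log units; beyond the scatter), but one end of that step is a limit: the limit of > 10000 nM in this assay, at which 1 of the 4 values shown sits.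

The compounds shown leave open how much of these values comes from the ethenyl chain and how much from the ring at its end, a question that thiophen-2-yl set directly on the carbonyl carbon, or a cyclohexyl ring on the ethenyl chain, would address. Also open, going by these compounds, is how a ring carrying an amine or a carboxylic acid would read at this place.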